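Cytotoxicity notes: removing the aromatic amino group

The source may report more compounds than this note shows. Statements on the series, on what has been measured and on what is new or still open speak of the compounds shown alone.

Compound 1 `Nc1cc(-c2ccccc2)ccc1Cn1cncc1CNc1ccc(Cl)c(-c2ccccc2)c1`; in a toxicity assay on NIH3T3 cells (Mus musculus) for cytotoxicity, read by resazurin assay (a lower number here means that less compound is needed, a higher number that more compound is needed for the effect), compound 1 gives > 1000 nM, which is a limit of the assay.
Compound 2 `COc1ccc(NCc2cncn2Cc2ccc(-c3ccccc3)cc2N)cc1-c1ccccc1`; in this assay compound 2 gives > 1000 nM, again a limit.
Compound 3 `Nc1cc(-c2ccccc2)ccc1Cn1cncc1CNc1ccc(-c2cncs2)c(-c2ccccc2)c1`; in this assay compound 3 gives > 1000 nM, also a limit.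

Compound 2 stands at the same limit as the other two measured compounds; no number is known for it, only that it sits at the limit of > 1000 nM in this assay, at which 3 of the 3 values shown sit. The steps between the measured compounds, a step that the two limits leave unreadable from compound 1 to compound 2, a step that the two limits leave unreadable from compound 1 to compound 3 and a step that the two limits leave unreadable from compound 2 to compound 3, all run between limits and cannot be sized. They concern the chloro, methoxy and 1,3-thiazol-5-yl groups, not the change considered here.

Compound 4 `COc1ccc(NCc2cncn2Cc2ccc(-c3ccccc3)cc2)cc1-c1ccccc1` differs from compound 2 by hydrogen in place of amino on an aromatic carbon. Going by the values given here, no measured step touches the amino group, so nothing speaks for a change in this assay beyond the scatter. Compound 4 is therefore expected to remain at the limit, with an estimated step that the limit leaves unreadable from compound 2 to compound 4. The estimate for compound 4 in this assay is 3000 nM, within 800 nM to 20000 nM.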

Compound 4, half-maximal effective concentration: > 1000 nM
Compound 4: only a limit was reported; the forecaster's own chance of this, stated with the estimate: 75%; the middle value is on the limit's open side.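

No step can be read from compound 2 to compound 4, because both sit at the same limit: the limit of > 1000 nM in this assay, at which 4 of the 4 values shown sit.

The compounds shown leave open how far past that limit each lies in this assay, and whether hydrogen in place of amino changes the read-out at all.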